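A few compounds are considered here, and "the series" means these few. Any claim that something is new, unique, unknown or untested is made for them only; others in the source may bear on it.

Measured compounds:
compound 1, `OC[C@H]1O[C@@H](n2cnc3c(NCc4ccc(F)cc4)ncnc32)[C@H](O)[C@@H]1O`: 21000 nM
compound 2, `OC[C@H]1O[C@@H](n2cnc3c(NCc4ccc(Cl)cc4)ncnc32)[C@H](O)[C@@H]1O`: > 166000 nM
compound 3, `OC[C@H]1O[C@@H](n2cnc3c(NCc4ccc(F)cc4Cl)ncnc32)[C@H](O)[C@@H]1O`: > 166000 nM

In a functional assay on MCF cells (Homo sapiens) for antiproliferative activity, with a stated time of 72 h (a lower number here means a stronger inhibitor, a higher number a weaker inhibitor), compound 1 gives 21000 nM. Compound 2 gives only > 166000 nM, which is a limit of the assay and not a number. Compound 3 likewise gives only > 166000 nM, again a limit. For the measured compounds named here, compound 1 therefore stands as the only compound with a read number; the other two sit at the limit of > 166000 nM in this assay, at which 2 of the 3 values shown sit. The steps read an at least 7.9-fold higher number from compound 1 to compound 2 (0.89 log units; beyond the scatter) and an at least 7.9-fold higher number from compound 1 to compound 3 (0.89 log units; beyond the scatter), while a step that the two limits leave unreadable from compound 2 to compound 3.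

Compound 4, `OC[C@H]1O[C@@H](n2cnc3c(NCc4cccc(O)c4O)ncnc32)[C@H](O)[C@@H]1O`, is not yet measured. It differs from compound 1 by 2,3-dihydroxyphenyl in place of 4-fluorophenyl on a saturated chain carbon bound to a nitrogen on an aromatic ring. Neither measured step concerns this change: both replace hydrogen or fluoro by chloro, whereas here 2,3-dihydroxyphenyl enters. Going by the values given here, the measured steps show only that changes on this ring can move the number to the limit. Compound 4 is expected to give 40000 nM (range 8000 nM to 166000 nM), with the estimated step being a 1.9-fold higher number from compound 1 to compound 4 (0.28 log units; within the scatter).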

Compound 4, half-maximal inhibitory concentration: 5200 nM
The estimate for compound 4 lay 7.7-fold (0.89 log units) above the measured number, outside the stated range (below it).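

At this position, on a saturated chain carbon bound to a nitrogen on an aromatic ring, the earlier compounds had shown only moves to higher numbers; in this assay the 2,3-dihydroxyphenyl group gives the first move the other way, with a 4.0-fold lower number from compound 1 to compound 4 (0.61 log units; beyond the scatter). Against the rings that carry chloro, the reach is larger, with an at least 31-fold lower number from compound 3 to compound 4 (1.50 log units; beyond the scatter) and an at least 31-fold lower number from compound 2 to compound 4 (1.50 log units; beyond the scatter). Both of these are bounds and not exact sizes, because compound 2 and compound 3 each rest on a limit: the limit of > 166000 nM in this assay, at which 2 of the 4 values shown sit.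

The compounds shown do not tell whether the lower number comes from the two hydroxyl groups together, from one of them alone, or from the loss of fluoro. Going by these compounds, whether a methoxy group or an amine on this ring would keep that number also remains open.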